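Removing the Ethyl Group: An Expected Inactive Analog

The source may report more compounds than this note shows. Statements on the series, on what has been measured and on what is new or still open speak of the compounds shown alone.

Compound 2 `CCC1(c2cccc(Cl)c2)ON=C(c2cccc(Cl)c2)O1` was tested in an ADME assay on HEK293 cells (Homo sapiens) for cytotoxicity, read by MTT assay, with a stated time of 44 h; on this read-out lower numbers stand for stronger inhibition and higher numbers for weaker inhibition. In this assay compound 2 gives only a limit of > 100000 nM, not a number. Its two closest relatives sit at the same limit. Compound 1 `Clc1cccc(C2=NOC(c3ccc(Cl)c(Cl)c3)O2)c1` gives a limit of > 100000 nM. Compound 3 `CCC1(c2cccc(Br)c2)ON=C(c2cccc(Cl)c2)O1` gives a limit of > 100000 nM. The step that the two limits leave unreadable from compound 2 to compound 3 therefore cannot be read, and all three results rest on (the limit of > 100000 nM in this assay, at which 3 of the 3 values shown sit). Compound 4 `Clc1cccc(C2=NOC(c3cccc(Cl)c3)O2)c1` differs from compound 2 by hydrogen in place of ethyl on a saturated ring carbon. Among the compounds with values here, no measured step tests this change, so the only guide is that every measured compound sits at the limit. The step that the limit leaves unreadable from compound 2 to compound 4 is therefore expected to be none beyond the scatter. Compound 4 is estimated at 150000 nM, within 50000 nM to 500000 nM, and most likely again reported only as a limit.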

Compound 4, half-maximal inhibitory concentration: > 100000 nM
Compound 4: no number, only a limit (the forecaster's own chance of this, stated with the estimate: 90%); the middle value is on the limit's open side.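

In this assay compound 4 also gives only a limit, so its steps from compound 2 and from compound 1 cannot be read: the limit of > 100000 nM in this assay, at which 4 of the 4 values shown sit.
Going by these compounds, whether any change to the shared core would give a readable number in this assay stays open.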